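Compound 2 and its stereoisomer, compound 4

This account rests on a few compounds, and the source may have more. Where it says the series, first, only, none or still open, it means among the compounds named here.

Measured in a functional assay on A549 cells (Homo sapiens) for cytotoxicity, read by MTT assay, with a stated time of 48 h; on this read-out higher numbers stand for weaker inhibition and lower numbers for stronger inhibition:
compound 1 `CCOC(=O)[C@@]1(C(=O)NCc2ccc(C)cc2)C[C@H]1c1cc(OC)c(OC)c(OC)c1`: 17100 nM
compound 2 `COc1cc([C@@H]2C[C@@]2(CO)C(=O)NCc2ccc(C)cc2)cc(OC)c1OC`: 46300 nM
compound 3 `COc1cc([C@@H]2C[C@@]2(CO)C(=O)Nc2ccccc2Cl)cc(OC)c1OC`: 11400 nM

Compound 2 holds the highest number of the three at 46300 nM, so it is the weakest of this small set. The next structure is compound 4 `COc1cc([C@H]2C[C@@]2(CO)C(=O)NCc2ccc(C)cc2)cc(OC)c1OC`, and the change is this: the two compounds have the same atoms and bonds and differ only in configuration as drawn: 1 of 2 stereo elements differ; a stereocentre at a saturated ring carbon is drawn S in compound 2 and R in compound 4. Among the compounds with values here, no measured step tests a change of configuration. Replacing ethoxycarbonyl with hydroxymethyl gave a 2.7-fold higher number from compound 1 to compound 2 (0.43 log units; beyond the scatter), and replacing 4-methylbenzyl with 2-chlorophenyl gave a 4.1-fold lower number from compound 2 to compound 3 (0.61 log units; beyond the scatter). Both are modest and both alter substituents, so they bear on the new change only by showing how far numbers have moved in this series. They give no direction for it. In this assay, no clear step is therefore expected, with only a slight lean toward a lower number since compound 2 sits at the top of the set. The estimate amounts to an expected 1.3-fold lower number from compound 2 to compound 4 (0.12 log units; within the scatter). The range stays wide, as a change of configuration could matter more than these steps suggest. Compound 4 is estimated at 35000 nM, with an expected range from 11000 nM to 100000 nM.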

Compound 4, half-maximal inhibitory concentration: 63800 nM
For compound 4 the middle estimate is 1.8-fold (0.26 log units) below the measured one; the measured number falls inside the stated range.
By their numbers in this assay, from the lowest: compounds 3 and 1 (each within the scatter of the next); then compounds 2 and 4 (each within the scatter of the next).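

In this assay, redrawing the stereocentre at a saturated ring carbon from S to R gave a 1.4-fold higher number from compound 2 to compound 4 (0.14 log units; within the scatter). This is the only measured test of configuration in the series, and with hydroxymethyl and 4-methylbenzyl in place, the change does not separate the pair, whereas the substituent steps were both printed as beyond the scatter. The comparison isolates configuration at this one centre because nothing else changes: the fact that compounds 2 and 4 differ only in the configuration as drawn

Going by these compounds, whether the same change would stay within the scatter with the 2-chlorophenyl amide of compound 3 or the ethoxycarbonyl of compound 1, and what the other stereo element contributes, remains open. Also open, on these data alone, is whether a carboxylic acid or an amine in place of hydroxymethyl would leave the two configurations as close.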